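A few compounds are considered here, and "the series" means these few. Any claim that something is new, unique, unknown or untested is made for them only; others in the source may bear on it.

Compound 1 `COc1cc(C2CC(c3ccccc3)=NN2C(=O)OCc2ccccc2)cc(OC)c1OC` and compound 2 `COc1cccc(C2=NN(C(=O)OCc3ccccc3)C(c3cc(OC)c(OC)c(OC)c3)C2)c1` were both tested in a functional assay on HepG2 cells (Homo sapiens) for antiproliferative activity, read by MTT assay, with a stated time of 48 h; a lower number here means a stronger inhibitor of growth, a higher number a weaker inhibitor of growth. For compound 1 the result is only a limit of the assay, > 10000 nM. For compound 2 the result is likewise only a limit, > 10000 nM. The change between them, (methoxy in place of hydrogen on an aromatic carbon), therefore gives a step that the two limits leave unreadable from compound 1 to compound 2, because both values sit at the limit of > 10000 nM in this assay, at which 2 of the 3 values shown sit. Compound 3 `COC(=O)N1N=C(c2ccccc2)CC1c1ccc(OC)c(OC)c1` has a core whose difference from compound 1 is not broken down here; in this assay compound 3 gives 9150 nM. Compound 4 `COC(=O)N1N=C(c2ccccc2)CC1c1cc(OC)c(OC)cc1OC` has not been measured; it differs from compound 3 by methoxy in place of hydrogen on an aromatic carbon. This is the same kind of change as that from compound 1 to compound 2, though the place differs: there the entering group was meta to a large group, here it is ortho to a large group, meta to a methoxy group and para to a methoxy group. Since the earlier step could not be read, compound 4 is expected to show a step of a 1.3-fold higher number from compound 3 to compound 4 (0.12 log units; within the scatter) from the value of compound 3, 9150 nM. The estimate for compound 4 in this assay is 12000 nM, between 4500 nM and 30000 nM.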

Compound 4, concentration for 50% growth inhibition: 6530 nM
The estimate for compound 4 lay 1.8-fold (0.26 log units) above the measured number, within the range that was stated.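

In this assay, adding the methoxy gives a 1.4-fold lower number from compound 3 to compound 4 (0.15 log units; within the scatter), so on the core of compound 3 this change produces no difference that can be told apart from the scatter. The same kind of change from compound 1 to compound 2 cannot be read, because both values are limits rather than numbers: the limit of > 10000 nM in this assay, at which 2 of the 4 values shown sit.

That leaves one readable step, which does not show whether the change carries from one core to the other.

The compounds shown leave open whether an amine, a carboxylic acid or a longer chain at this place would give a step beyond the scatter. Also open, going by these compounds, is what a methoxy does on the core of compound 1 when both values are numbers.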